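The source may hold more compounds than are shown below. What is called first, only, known or untested is meant among the compounds shown, and "the series" means these compounds.

Compound 1 `CC(c1ccc(-c2ccccc2)c(F)c1)c1nnc2n1N=C(c1ccc(Cl)cc1)CS2`: 3900 nM
Compound 2 `COc1ccc2cc(C(C)c3nnc4n3N=C(c3ccc(C)cc3)CS4)ccc2c1`: 8200 nM
Compound 3 `Cc1ccc(C2=Nn3c(nnc3C(C)c3ccc(-c4ccccc4)c(F)c3)SC2)cc1`: 7200 nM

In a functional assay on Huh-7 cells (Homo sapiens) for inhibition, read by sulforhodamine B assay, with a stated time of 72 h (on this read-out higher numbers stand for weaker inhibition and lower numbers for stronger inhibition), compound 2 gives the highest of the three numbers; its gap to compound 3 lies within the scatter, its gap to compound 1 beyond it. Compound 4 `COc1ccc2cc(C(C)c3nnc4n3N=C(c3ccc(F)cc3)CS4)ccc2c1` differs from compound 2 by fluoro in place of methyl on an aromatic carbon. Within the data shown here, the only measured step touching this aromatic carbon, a 1.8-fold higher number from compound 1 to compound 3 (0.27 log units; within the scatter), exchanged chloro for methyl and stayed within the scatter; it is the sole guide for the present exchange of methyl for fluoro. A small step is therefore expected, leaning if anything toward a lower number, following the direction seen in compound 1 against compound 3. Compound 4 is expected at 6500 nM, with a range of 3000 nM to 14000 nM, a step of a 1.3-fold lower number from compound 2 to compound 4 (0.10 log units; within the scatter) that is expected to remain within the scatter.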

Compound 4, half-maximal inhibitory concentration: 7000 nM
Beside the measured number, compound 4's estimate is 1.1-fold (0.03 log units) below it, within the range that was stated.
By their numbers in this assay, from the lowest: compounds 1, 4, 3 and 2 (each within the scatter of the next, the first and the last beyond it).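

In this assay, the change from 4-methylphenyl to 4-fluorophenyl gives a 1.2-fold lower number from compound 2 to compound 4 (0.07 log units; within the scatter) on a background that differs from the one behind a 1.8-fold higher number from compound 1 to compound 3 (0.27 log units; within the scatter) and is the second exchange at this aromatic carbon to stay within the scatter. Methyl, chloro and fluoro have thus each been read here, with no step beyond the scatter. The data offer no measurement that bears on why these steps are small. Still open, as far as these compounds go, is whether an amine or a carboxylic acid at this aromatic carbon would move the number beyond the scatter.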